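Swapping One Aryl Group in a Growth-Inhibiting Series

The source may hold more compounds than are shown below. What is called first, only, known or untested is meant among the compounds shown, and "the series" means these compounds.

In a functional assay on U-251 cells (Homo sapiens) for cytotoxicity (on this read-out higher numbers stand for weaker inhibition of growth and lower numbers for stronger inhibition of growth), compound 1 `COc1ccc(C2=C(c3cc(OC)c(OC)c(OC)c3)CC3CCCN3C2=O)cc1O` gives only a limit of the assay, > 100000 nM. Two compounds give actual numbers: compound 2 `COc1ccc(C2=C(c3ccc(SC)cc3)CC3CCCN3C2=O)cc1OC(=O)C1CCCN1C(=O)OC(C)(C)C` has 2000 nM, and compound 3 `CSc1ccc(C2=C(c3ccc(C)c(C)c3)C(=O)N3CCCC3C2)cc1` has 10000 nM. Compound 3 therefore has the higher of the two numbers, which makes it the weaker growth inhibitor of this pair.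

Compound 4 `CSc1ccc(C2=C(c3ccc(Br)cc3)C(=O)N3CCCC3C2)cc1` carries 4-bromophenyl in place of 3,4-dimethylphenyl on a double-bonded ring carbon. Within the data shown here, no measured pair of compounds shows a change in this one place, so any forecast is uncertain. A modest move towards stronger inhibition in this assay is expected, estimated as a 2.0-fold lower number from compound 3 to compound 4 (0.30 log units; within the scatter). The expected value for compound 4 is 5000 nM, with an estimated range of 1500 nM to 20000 nM.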

Compound 4, concentration for 50% growth inhibition: 7000 nM
For compound 4 the middle estimate is 1.4-fold (0.15 log units) below the measured one; measured number inside the range.
By their numbers in this assay, from the lowest: compound 2; then compounds 4 and 3 (each within the scatter of the next). At a limit, above all of these: compound 1.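

Replacing 3,4-dimethylphenyl with 4-bromophenyl on this double-bonded ring carbon gives a 1.4-fold lower number from compound 3 to compound 4 (0.15 log units; within the scatter) in this assay, so the swap leaves the reading effectively unchanged. Among these compounds, this is the only measured pair that differs in this one place, and it shows that these two aromatic rings of carbon, neither with hydrogen-bond donors or acceptors, read alike here. Nothing measured explains why these two groups read alike.

Still open, from the compounds shown here alone, is whether a phenyl ring carrying an amine or a carboxylic acid at this position would shift the number. Going by these compounds, a pyridine ring, with nitrogen in the ring itself, remains an equally open case.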